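Halogen for ethyl on the aniline ring of compound 1

A few compounds are considered here, and "the series" means these few. Any claim that something is new, unique, unknown or untested is made for them only; others in the source may bear on it.

Measured so far in a functional assay on MCF7 cells (Homo sapiens) for inhibition; a lower number here means a stronger inhibitor, a higher number a weaker inhibitor:
Compound 1, `CCc1cc(N)ccc1-c1nc2ccccc2s1`, gives < 0.1 nM, a limit of the assay.
Compound 2, `Cc1ccc2nc(-c3ccc(N)cc3Br)sc2c1`, gives < 0.1 nM, again a limit.
Compound 3, `Nc1cc(Br)c(-c2nc3ccccc3o2)c(Br)c1`, gives < 10 nM, also a limit.

Compound 1 stands only as a limit in this assay, not as a number; no measured step between any pair of these compounds is available, so the three values show no more than that two sit at the limit of < 0.1 nM in this assay, at which 2 of the 3 values shown sit, and one at the limit of < 10 nM in this assay, at which 1 of the 3 values shown sits.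

The next compound, compound 4, `Nc1ccc(-c2nc3ccccc3s2)c(I)c1`, differs from compound 1 in one place: iodo in place of ethyl on an aromatic carbon, on an aromatic carbon of a six-membered aromatic ring of carbon only, ortho to a group of 9 heavy atoms and meta to an amino group. Going by the values given here, since compound 1 is known only as a limit, no step in this assay can be expected in either direction beyond the scatter; compound 2, which carries a bromo group in the corresponding place, likewise sits at < 0.1 nM as a limit.

Compound 4 is therefore expected to give about 0.1 nM in this assay, between 0.02 nM and 0.6 nM, and the expected step from compound 1 to compound 4 is a number no lower from compound 1 to compound 4 (the limit leaves the size open), most likely reported again as a limit.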

Compound 4, half-maximal inhibitory concentration: < 0.1 nM
Compound 4: a limit, no number; the forecaster's own chance of this, stated with the estimate: 60%; the middle value lies on the limit itself.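

Going by these compounds alone, compound 1 and compound 4 both stand only as limits in this assay, so no step between them can be read. The compounds shown leave open whether iodo in place of ethyl on an aromatic carbon changes inhibition at all, and what numbers compound 1 and compound 4 would actually give.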